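Inverting One Stereocentre: Expected Half-Life of Compound 3

The source may hold more compounds than are shown below. What is called first, only, known or untested is meant among the compounds shown, and "the series" means these compounds.

Compound 1 `Cn1cc([C@@H](O)[C@H]2C(=O)N3C(C(=O)O)=C(C(C)(C)C)O[C@H]23)nn1` gives 6.8 h in an ADME assay, in phosphate buffer, at 28 degrees C, at pH 7.0; a lower number here means that the compound disappears faster, a higher number that the compound lasts longer.
Compound 2 `CC(C)(C)C1=C(C(=O)O)N2C(=O)[C@H]([C@H](O)CCc3ccccc3)[C@H]2O1` gives 21 h in this assay.

Going by the values given here, compound 1 holds the lower of the two numbers; the step to its only neighbour is a 3.1-fold higher number from compound 1 to compound 2 (0.49 log units; beyond the scatter). Compound 3 `Cn1cc([C@H](O)[C@H]2C(=O)N3C(C(=O)O)=C(C(C)(C)C)O[C@H]23)nn1` is drawn with the two compounds have the same atoms and bonds and differ only in configuration as drawn: 1 of 3 stereo elements differ; a stereocentre at a saturated chain carbon is drawn S in compound 1 and R in compound 3. Among the compounds with values here, the single measured step swaps a group, not a configuration, so it offers no guide here. With no stereo comparison measured, the expected step is no change at the digits printed from compound 1 to compound 3 (within the scatter), within the scatter. Compound 3 is therefore estimated at 6.8 h, with a range from 3 h to 15 h.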

Compound 3, half-life: 7 h
For compound 3 the middle estimate is 1.0-fold (0.01 log units) below the measured one; low and high end bracket the measured number.
By their numbers in this assay, from the lowest: compounds 1 and 3 (each within the scatter of the next); then compound 2.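

In this assay, inverting the stereocentre at the saturated chain carbon from S to R gives a 1.0-fold higher number from compound 1 to compound 3 (0.01 log units; within the scatter), so the half-life does not tell the two configurations apart when 1-methyl-1H-1,2,3-triazol-4-yl is the group at this position. The earlier step swapped a group, whereas this one isolates configuration, and that reading rests on one point: the fact that compounds 1 and 3 differ only in the configuration as drawn.

On these data alone, whether the same holds with phenethyl at this position stays open. So does how the half-life would respond to an amine in place of the oxygen on that carbon.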